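Quinoline ketone series: removing the methyl from compound 1

The source may report more compounds than this note shows. Statements on the series, on what has been measured and on what is new or still open speak of the compounds shown alone.

Measured so far in an assay for inhibition of 17-beta-hydroxysteroid dehydrogenase type 1 (Homo sapiens), read by HPLC, with a stated time of 10 min, tested at 1 uM; on this read-out lower numbers stand for less inhibition and higher numbers for more inhibition at the one concentration tested (going by the name of the read-out):
compound 1 `Cc1ccc2nc(C(=O)c3ccc(F)c(O)c3)ccc2c1` gives 12%
compound 2 `O=C(c1ccc(F)c(O)c1)c1ccc2ccccc2c1` gives 64%
compound 3 `Oc1cc(Nc2cccc(-c3cccc(O)c3F)n2)ccc1F` gives 57%

Compound 1 stands lowest of the three numbers in this assay. The nearest is compound 3, whose number lies higher by a margin beyond the scatter; compound 2 lies further still, also beyond the scatter. For the measured compounds named here, none of these three pairs differs in a single place, so the numbers show only that the core of compound 1 reads low where the others read moderate to high, and nothing is inferred about which part of the structure carries the gap.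

Compound 4 `O=C(c1ccc(F)c(O)c1)c1ccc2ccccc2n1` is the untested neighbour of compound 1. The difference is hydrogen in place of methyl on an aromatic carbon, a removal of one carbon from the fused two-ring system.

Going by the values given here, with no single-place step measured anywhere, the size of the effect has no precedent here. A loss of one carbon from a ring is small, and the expectation in this assay is for no step beyond the scatter, with the direction open. The step from compound 1 to compound 4 is expected to be a number 6 percentage points higher from compound 1 to compound 4 (within the scatter). For compound 4 the estimate in this assay is 18%, expected to fall between 3% and 40%.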

Compound 4, a percentage reported as inhibition, at one concentration (the size of the read-out at that concentration, not a potency): 6%
Compound 4: middle estimate off by 12 percentage points, on the high side; the measured number falls inside the stated range.
By their numbers in this assay, from the lowest: compounds 4 and 1 (each within the scatter of the next); then compounds 3 and 2 (each within the scatter of the next).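

In this assay, for the compounds shown here, the first single-place step, hydrogen in place of methyl on an aromatic carbon, reads as a number 6 percentage points lower from compound 1 to compound 4 (within the scatter). At this carbon, meta to a fused ring and para to a fused ring, the methyl therefore does not separate compound 4 from compound 1 by more than the scatter, and the low reading of the core of compound 1 persists without this group. No supporting data on hand speak to why this step has the size it has.

Open, as far as these compounds go, is whether a different group on the same aromatic carbon, such as methoxy, an amine, a carboxylic acid or a longer chain like propyl, would move the number beyond the scatter, and with compound 4 at 6% there is little room left to read any further fall at the single concentration tested. Also open, from the compounds shown here alone, is whether the exchange of methyl for hydrogen gives a step of similar size on a core that reads higher, such as that of compound 2, since the present step comes from the low end of the series alone.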